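Iodo for Amino at the Far Aryl Ring

This account rests on a few compounds, and the source may have more. Where it says the series, first, only, none or still open, it means among the compounds named here.

Measured so far:
Compound 1, `CC(C)(C)c1cc(N)c2cc(NC(=O)/C=C/c3ccc(C(F)(F)F)cc3)ccc2n1`: 0.3 nM
Compound 2, `CCCc1cc(N)c2cc(NC(=O)/C=C/c3ccc(N)cc3)ccc2n1`: 190 nM

In an assay on isolated protein for displacement of a labelled ligand from melanin-concentrating hormone receptor 1 (Homo sapiens) (on this read-out lower numbers stand for stronger inhibition and higher numbers for weaker inhibition), compound 2 gives 190 nM and so stands at the higher end of the two numbers; compound 1, the nearest neighbour, gives 0.3 nM, a much lower number and a gap well beyond the scatter. Among the compounds with values here, the two differ at two places, so no single step between them can be read.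

Compound 3, `CCCc1cc(N)c2cc(NC(=O)/C=C/c3ccc(I)cc3)ccc2n1`, is the unmeasured compound. It keeps the core and the propyl chain of compound 2 and changes only the group on the aromatic carbon of the six-membered carbon-only ring, para to a large group: iodo in place of amino on an aromatic carbon. In the same words, 4-aminophenyl becomes 4-iodophenyl.

Within the data shown here, no step of this kind is known here. Compound 1 carries a trifluoromethyl at that place and gives 0.3 nM in this assay. Compound 3 is therefore expected to move toward lower numbers, with the step of a 32-fold lower number from compound 2 to compound 3 (1.50 log units; beyond the scatter) estimated to lie beyond the scatter. Compound 3 is estimated at 6 nM, within a range from 1 nM to 40 nM.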

Compound 3, half-maximal inhibitory concentration: 2.3 nM
Estimate against measurement, compound 3: 2.6-fold (0.42 log units) above; measured number inside the range.
By their numbers in this assay, from the lowest: compound 1; then compound 3; then compound 2.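

In this assay, iodo in place of amino on an aromatic carbon, para to a large group, gives an 83-fold lower number from compound 2 to compound 3 (1.92 log units; beyond the scatter), the only step that can be read among these compounds. With the core and the propyl chain held fixed, it shows that this single change at the far aryl ring is enough on its own to move the number far beyond the scatter. Amino brings one hydrogen-bond donor and one hydrogen-bond acceptor, while iodo brings neither, so neither count is needed at this place for a low number in this assay, and nothing available here explains the size of the step.

One step cannot separate what iodo adds from what the loss of amino removes, so a plain hydrogen, a chlorine or a methoxy group at this place would be needed to tell the two apart. Within the data shown here, compound 1 differs from compound 3 in two places, so no step between them can be read, and the separate effects of its trifluoromethyl group and of its chain at the core, as against the propyl chain or a longer chain, remain open.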